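Chloro for trifluoromethyl on a benzylated sulfonamide: expectation

A few compounds are considered here, and "the series" means these few. Any claim that something is new, unique, unknown or untested is made for them only; others in the source may bear on it.

Measured compounds:
compound 1 `CCOC(=O)c1oc2ccc(NS(=O)(=O)c3ccc(C(F)(F)F)cc3)cc2c1C`
compound 2 `CCOC(=O)c1oc2ccc(NS(=O)(=O)c3ccc(Cl)cc3)cc2c1C`
compound 3 `CCOC(=O)c1oc2ccc(N(Cc3ccccc3)S(=O)(=O)c3ccc(C(F)(F)F)cc3)cc2c1C`

All three were run in a functional assay on HCT-116 cells (Homo sapiens) for inhibition, read by MTT assay, with a stated time of 72 h; a lower number here means a stronger inhibitor, a higher number a weaker inhibitor. Compound 1 gives 24200 nM. Compound 3 gives 12700 nM. Compound 2 returns no number but a limit, > 40000 nM, which is the limit of > 40000 nM in this assay, at which 1 of the 3 values shown sits.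

Compound 2 differs from compound 1 by chloro in place of trifluoromethyl on an aromatic carbon; the step is an at least 1.6-fold higher number from compound 1 to compound 2 (0.21 log units; that floor lies within the scatter). Compound 3 differs from compound 1 by benzyl in place of hydrogen on a sulfonamide nitrogen; the step is a 1.9-fold lower number from compound 1 to compound 3 (0.28 log units; within the scatter).

Compound 4 `CCOC(=O)c1oc2ccc(N(Cc3ccccc3)S(=O)(=O)c3ccc(Cl)cc3)cc2c1C` is not yet measured. It differs from compound 3 by chloro in place of trifluoromethyl on an aromatic carbon, the same change as from compound 1 to compound 2, at the same place. For compound 4 the expected step is a 2.2-fold higher number from compound 3 to compound 4 (0.34 log units; beyond the scatter), resting on an at least 1.6-fold higher number from compound 1 to compound 2 (0.21 log units; that floor lies within the scatter). Compound 4 is therefore estimated at 28000 nM, likely between 14000 nM and 60000 nM, with a real chance that only a limit is returned.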

Compound 4, half-maximal inhibitory concentration: 23200 nM
Beside the measured number, compound 4's estimate is 1.2-fold (0.08 log units) above it; measured number inside the range.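

In this assay the change from trifluoromethyl to chloro on the benzylated sulfonamide gives a 1.8-fold higher number from compound 3 to compound 4 (0.26 log units; within the scatter) and the benzyl change on the chloro compounds gives an at least 1.7-fold lower number from compound 2 to compound 4 (0.23 log units; that floor lies within the scatter). The first of these steps lies within the scatter, so it shows no firm effect of the change on this core, and it does not show that the change carries over unaltered: the same change on two cores in this assay, an at least 1.6-fold higher number (0.21 log units; that floor lies within the scatter) from compound 1 to compound 2 and a 1.8-fold higher number (0.26 log units; within the scatter) from compound 3 to compound 4; the limit leaves it open whether they differ. The value of compound 2 is only a limit, and the benzyl change stays equally undecided: the same change on two cores in this assay, a 1.9-fold lower number (0.28 log units; within the scatter) from compound 1 to compound 3 and an at least 1.7-fold lower number (0.23 log units; that floor lies within the scatter) from compound 2 to compound 4; the limit leaves it open whether they differ.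

Open, from the compounds shown here alone, is whether a nitrile or a methoxy group on the aromatic ring would take the number beyond the scatter. Open too, going by these compounds, are a carboxylic acid in place of the ethyl ester and a longer chain or an amine on the sulfonamide nitrogen.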